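Working notes: the step from compound 3 to compound 4

This account rests on a few compounds, and the source may have more. Where it says the series, first, only, none or still open, it means among the compounds named here.

The series is read in an ADME assay on cells (Peritoneal macrophage, Mus musculus) for cytotoxicity, read by CCK-8 assay, with a stated time of 24 h (a higher number here means that more compound is tolerated, a lower number that less compound is tolerated), and every result so far is a limit of the assay, not a number. Compound 1 `COc1ccc(S(=O)(=O)N(CC(N)=O)c2ccc(N(CC(N)=O)S(=O)(=O)c3ccc(SCCCCN=C=S)cc3)c3ccccc23)cc1` gives > 10000 nM as a limit. Compound 2 `COc1ccc(S(=O)(=O)N(CC(N)=O)c2ccc(N(CC(N)=O)S(=O)(=O)c3ccc(S(=O)(=O)CCCN=C=S)cc3)c3ccccc23)cc1` gives > 10000 nM as a limit. Compound 3 `COc1ccc(S(=O)(=O)N(CC(N)=O)c2ccc(N(CC(N)=O)S(=O)(=O)c3ccc(S(=O)(=O)CCOCCN=C=S)cc3)c3ccccc23)cc1` gives > 10000 nM as a limit. Compound 3 therefore stands at the same limit as the other two (the limit of > 10000 nM in this assay, at which 3 of the 3 values shown sit) and has no rank among them.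

Compound 4 `COc1ccc(S(=O)(=O)N(CC(N)=O)c2ccc(N(CC(N)=O)S(=O)(=O)c3ccc(N=C=S)cc3)c3ccccc23)cc1` is not yet measured. Its change from compound 3 is a group of 3 heavy atoms (1 carbon, 1 nitrogen, 1 sulfur; no ring) in place of a group of 11 heavy atoms (5 carbon, 1 nitrogen, 3 oxygen, 2 sulfur; no ring), on an aromatic carbon and it falls on an aromatic carbon of a six-membered aromatic ring of carbon only, para to a large group. Going by the values given here, three measured steps touch this group: a step that the two limits leave unreadable from compound 1 to compound 2 and a step that the two limits leave unreadable from compound 1 to compound 3 and a step that the two limits leave unreadable from compound 2 to compound 3 and none has a readable size. Among the compounds with values here, no measured compound carries the smaller group that enters in compound 4. Given a step that the two limits leave unreadable from compound 1 to compound 3 for compound 3 no step beyond the scatter is expected and no direction can be assigned. The estimated change is a step that the limit leaves unreadable from compound 3 to compound 4 and it remains a weak expectation. Compound 4 is estimated at 12000 nM with an expected range of 4000 nM to 30000 nM and a limit is the likeliest report.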

Compound 4, half-maximal cytotoxic concentration: > 10000 nM
Compound 4: a limit, no number (the forecaster's own chance of this, stated with the estimate: 70%); the middle value lies beyond the limit too.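

Compound 4 joins compound 1, compound 2 and compound 3 at the same limit, so no step among these compounds can be read, because none of the results is a number: the limit of > 10000 nM in this assay, at which 4 of the 4 values shown sit. The compounds shown leave open whether the changes on the aromatic carbon make any difference in this assay.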